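Cyclopropyl in place of ethyl on the amide carbonyl

This account rests on a few compounds, and the source may have more. Where it says the series, first, only, none or still open, it means among the compounds named here.

Compound 1 `CCn1c(-c2cnc(C)nc2)nc2c(N[C@H]3CCN(C(=O)C4CCOC4)C3)ncnc21`: 0.7 L/kg
Compound 2 `CCn1c(-c2cnc(C)nc2)nc2c(N[C@H]3CCN(C(=O)N4CC(OC)C4)C3)ncnc21`: 0.7 L/kg
Compound 3 `CCC(=O)N1CC[C@H](Nc2ncnc3c2nc(-c2cnc(C)nc2)n3CC)C1`: 1 L/kg

In an ADME assay (Rattus norvegicus, strain Wistar Han) for pharmacokinetics (a higher number here means that more of the compound sits outside the plasma, a lower number that more of the compound stays in the plasma), compound 3 shows the highest of the three numbers, but the steps of a 1.4-fold higher number from compound 1 to compound 3 (0.15 log units; within the scatter) and a 1.4-fold higher number from compound 2 to compound 3 (0.15 log units; within the scatter) both fall within the scatter, so the three compounds cannot really be told apart. Compound 4 `CCn1c(-c2cnc(C)nc2)nc2c(N[C@H]3CCN(C(=O)C4CC4)C3)ncnc21` differs from compound 3 by cyclopropyl in place of ethyl on a carbonyl carbon. Every change at this carbonyl carbon measured so far, no change at the digits printed from compound 1 to compound 2 (within the scatter) as well as a 1.4-fold higher number from compound 1 to compound 3 (0.15 log units; within the scatter) and a 1.4-fold higher number from compound 2 to compound 3 (0.15 log units; within the scatter), stayed within the scatter, and on that basis no step beyond the scatter is expected for no change at the digits printed from compound 3 to compound 4 (within the scatter). Compound 4 is therefore estimated at 1 L/kg, with a range from 0.6 L/kg to 1.6 L/kg.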

Compound 4, volume of distribution: 1 L/kg
The estimate for compound 4 equals the measured number at the digits printed; measured number inside the range.
By their numbers in this assay, from the lowest: compounds 1, 2, 3 and 4 (each within the scatter of the next).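

Cyclopropyl in place of ethyl on the amide carbonyl gives no change at the digits printed from compound 3 to compound 4 (within the scatter) in this assay and so adds a small all-carbon ring to this position without a readable shift. Against the two larger groups, the same position gives a 1.4-fold higher number from compound 2 to compound 4 (0.15 log units; within the scatter) and a 1.4-fold higher number from compound 1 to compound 4 (0.15 log units; within the scatter) and thus shows that all four groups at this carbonyl carbon remain indistinguishable in this measurement. Nothing measured explains this flat result. Open, going by these compounds, is whether an amine, a carboxylic acid or a longer chain on this carbonyl carbon would move the number beyond the scatter.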